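Hydroxy in Place of Nitro on a Sulfamoyl Carbamate

The source may report more compounds than this note shows. Statements on the series, on what has been measured and on what is new or still open speak of the compounds shown alone.

Three compounds carry the same sulfonyl-bridged linker between an aryl group bearing two isopropyl groups and a varied second half. In an assay on liver for inhibition of sterol O-acyltransferase 1 (Rattus norvegicus), using microsomes (a higher number here means a weaker inhibitor, a lower number a stronger inhibitor), compound 1 `CCCCCCCCCCCCCCCCCCN(C)S(=O)(=O)NC(=O)Nc1c(C(C)C)cccc1C(C)C` gives 1900 nM. Compound 2 `CCCCCCC(C)OS(=O)(=O)NC(=O)Nc1c(C(C)C)cccc1C(C)C` gives 35000 nM in this assay. Compound 3 `CC(C)c1cc([N+](=O)[O-])cc(C(C)C)c1OC(=O)NS(=O)(=O)Oc1c(C(C)C)cccc1C(C)C` reaches only the limit of this assay, reported as > 50000 nM, which places it at the limit of > 50000 nM in this assay, at which 1 of the 3 values shown sits. Within the data shown here, no step between any two of these measured compounds has been worked out; the values of compound 1 and compound 2 simply differ as they stand.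

Compound 4 `CC(C)c1cc(O)cc(C(C)C)c1OC(=O)NS(=O)(=O)Oc1c(C(C)C)cccc1C(C)C` differs from compound 3 by hydroxy in place of nitro on an aromatic carbon, meta to two isopropyl groups and para to a large group. Because compound 3 sits at the limit of > 50000 nM in this assay, at which 1 of the 3 values shown sits, the size of the step from it cannot be read from a number on its side; any gain would first have to bring compound 4 into the measurable range. Compound 4 is expected to give 40000 nM in this assay, somewhere between 10000 nM and 200000 nM. The estimated step of an at least 1.2-fold lower number from compound 3 to compound 4 (0.09 log units; that floor lies within the scatter) is expected to be small, leaving compound 4 a weak inhibitor.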

Compound 4, half-maximal inhibitory concentration: > 50000 nM
Compound 4 ended at the assay's limit; the forecaster's own chance of this, stated with the estimate: 45%; middle value at least 1.2-fold (0.09 log units) away from the limit.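

Compound 3 and compound 4 both stand at a limit of this assay rather than at a number, so no step between them can be read: the limit of > 50000 nM in this assay, at which 2 of the 4 values shown sit.

Whether hydroxy in place of nitro on an aromatic carbon changes inhibition at all remains open in the compounds shown.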